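A cyano group on the benzoyl of compound 3

A few compounds are considered here, and "the series" means these few. Any claim that something is new, unique, unknown or untested is made for them only; others in the source may bear on it.

Three measured compounds share one core and differ only in the group on the carbonyl carbon. Compound 1 `CC(C)C(=O)Nc1c(C(O)(C(F)(F)F)C(F)(F)F)ccc2ccccc12` gives 6630 nM in an assay on LtK cells with ATP-sensitive inward rectifier potassium channel 11 (Homo sapiens) as the target; on this read-out higher numbers stand for an effect only at larger amounts of compound and lower numbers for an effect already at smaller amounts. Compound 2 `O=C(CCc1ccccc1)Nc1c(C(O)(C(F)(F)F)C(F)(F)F)ccc2ccccc12` gives 1750 nM in this assay, and compound 3 `O=C(Nc1c(C(O)(C(F)(F)F)C(F)(F)F)ccc2ccccc12)c1ccccc1` gives 44 nM. Compound 3 stands lowest of the three numbers, with a 150-fold lower number from compound 1 to compound 3 (2.18 log units; beyond the scatter) and a 40-fold lower number from compound 2 to compound 3 (1.60 log units; beyond the scatter); the remaining step is a 3.8-fold lower number from compound 1 to compound 2 (0.58 log units; beyond the scatter).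

Compound 4 `N#Cc1cccc(C(=O)Nc2c(C(O)(C(F)(F)F)C(F)(F)F)ccc3ccccc23)c1` carries the change (cyano in place of hydrogen on an aromatic carbon). The measured steps all exchange the whole group on the carbonyl carbon; none adds a substituent to a phenyl already in place. They bear on the step to compound 4 only in fixing the benzoyl of compound 3 as the starting point, and they say nothing about a cyano on that phenyl. With no direct comparison, no step beyond the scatter is expected in this assay, and the estimated step is a 1.0-fold higher number from compound 3 to compound 4 (0.01 log units; within the scatter). For compound 4 the estimate is 45 nM, within a range of 12 nM to 170 nM.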

Compound 4, half-maximal effective concentration: 12 nM
For compound 4 the middle estimate is 3.8-fold (0.57 log units) above the measured one; the measured number falls inside the stated range.
By their numbers in this assay, from the lowest: compound 4; then compound 3; then compound 2; then compound 1.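

In this assay the phenyl of the benzoyl is not the end point of this series: cyano in place of hydrogen on an aromatic carbon, meta to a large group, gives a 3.7-fold lower number from compound 3 to compound 4 (0.56 log units; beyond the scatter) and adds to the gain already seen from exchanging the whole group. Against the other groups on the carbonyl carbon, 3-cyanophenyl gives a 150-fold lower number from compound 2 to compound 4 (2.16 log units; beyond the scatter) for phenethyl and a 550-fold lower number from compound 1 to compound 4 (2.74 log units; beyond the scatter) for isopropyl, both large steps. No measurement at hand accounts for the step to the nitrile.

Only one substituent at one place on this phenyl is shown, so it stays open whether the gain belongs to cyano or to substitution at this carbon generally. An amine, a carboxylic acid or a methoxy group on the same carbon would help to separate the two.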